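Phenyl to Pyridin-2-yl in Two Ester Pairs

The compounds below may be only part of what the source reports. "The series", "measured", "known", "first", "only" and "open" are said of these compounds alone.

Measured so far, in a functional assay on NIH3T3 cells (Mus musculus) for inhibition, read by MTT assay, with a stated time of 72 h; a lower number here means a stronger inhibitor, a higher number a weaker inhibitor:
compound 1 `C=C1CC[C@H]2[C@@](C)(CC[C@@H](OC(C)=O)[C@@]2(C)C(=O)OCc2ccccc2)[C@@H]1CCC1=CCOC1=O` gives 12900 nM;
compound 2 `C=C1CC[C@H]2[C@@](C)(CC[C@@H](OC(C)=O)[C@@]2(C)C(=O)OCc2ccccn2)[C@@H]1CCC1=CCOC1=O` gives 55500 nM;
compound 3 `C=C1CC[C@H]2[C@@](C)(CC[C@@H](O)[C@@]2(C)C(=O)OCc2ccccc2)[C@@H]1/C=C/C1=CCOC1=O` gives 13600 nM.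

Compound 2 differs from compound 1 by pyridin-2-yl in place of phenyl on a saturated chain carbon bound to an oxygen next to a carbonyl group, and that single change produced a 4.3-fold higher number from compound 1 to compound 2 (0.63 log units; beyond the scatter). Compound 3 rests on a different core; how its core differs from that of compound 1 is not broken down here, and the two values lie within the scatter of each other. Compound 4 `C=C1CC[C@H]2[C@@](C)(CC[C@@H](O)[C@@]2(C)C(=O)OCc2ccccn2)[C@@H]1/C=C/C1=CCOC1=O` has not yet been measured. Among the measured compounds shown here, it differs from compound 3 by pyridin-2-yl in place of phenyl on a saturated chain carbon bound to an oxygen next to a carbonyl group, the same change at the same place as the one separating compound 1 and compound 2. For the measured compounds named here, since the only earlier instance of this change is a 4.3-fold higher number from compound 1 to compound 2 (0.63 log units; beyond the scatter), compound 4 is expected to show a 4.0-fold higher number from compound 3 to compound 4 (0.61 log units; beyond the scatter) in this assay. Compound 4 is therefore estimated at 55000 nM, with a range from 20000 nM to 150000 nM.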

Compound 4, half-maximal inhibitory concentration: 80200 nM
Compound 4: middle estimate off by 1.5-fold (0.16 log units), on the low side; the range from low to high includes it.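

In this assay, pyridin-2-yl in place of phenyl gave a 5.9-fold higher number from compound 3 to compound 4 (0.77 log units; beyond the scatter), and this step cannot be told apart in size from the one seen earlier on the other core: the same change on two cores in this assay, a 4.3-fold higher number (0.63 log units; beyond the scatter) from compound 1 to compound 2 and a 5.9-fold higher number (0.77 log units; beyond the scatter) from compound 3 to compound 4, 1.4-fold (0.14 log units) apart, within the scatter of two such steps. Across these two cores, then, the change carried over in both direction and size, giving a weaker inhibitor in each pair. Among the compounds shown here, this rests on only two pairs in one cell assay, so it does not show that the change would carry over to any further core, or whether any feature of these cores affects its size.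

The compounds shown leave open how cyclohexyl or methyl in place of phenyl would behave at this place. They also leave open what an amine or a carboxylic acid on the phenyl ring would do to the number.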